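The compounds below may be only part of what the source reports. "The series", "measured", "known", "first", "only" and "open" are said of these compounds alone.

Three ureas built on a shared core have been tested in an ADME assay on HepG2 cells (Homo sapiens) for cytotoxicity, with a stated time of 72 h; a lower number here means that less compound is needed, a higher number that more compound is needed for the effect. Compound 1 `Cc1cc(NC(=O)Nc2ccc(Cl)c(Cl)c2)c2ccccc2n1` is the only one of them to return a number: in this assay compound 1 gives 17000 nM. Compound 2 `CSc1ccccc1NC(=O)Nc1cc(C)nc2ccccc12` returns only a limit of the assay, > 25000 nM. Compound 3 `Cc1cc(NC(=O)Nc2cnc3ccccc3c2)c2ccccc2n1` likewise returns only a limit of the assay, > 25000 nM. For the measured compounds named here, compound 1 therefore stands alone as the one measured value, set against (the limit of > 25000 nM in this assay, at which 2 of the 3 values shown sit). Compound 4 `Cc1cc(NC(=O)Nc2cccc(Cl)c2)c2ccccc2n1` differs from compound 1 in a single place: hydrogen in place of chloro on an aromatic carbon. Going by the values given here, no step between two measured compounds is at hand to gauge the size of this change, and compound 1 is the only number available for comparison. With so little to go on, the expectation in this assay is for no movement beyond the usual scatter, and a step of about a 1.2-fold higher number from compound 1 to compound 4 (0.07 log units; within the scatter) is estimated. Compound 4 is thus expected to give around 20000 nM, within a range of 8000 nM to 50000 nM, with a real chance that only a limit is reported.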

Compound 4, half-maximal effective concentration: 19000 nM
The estimate for compound 4 lay 1.1-fold (0.02 log units) above the measured number; measured number inside the range.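

In this assay, hydrogen in place of chloro on this aromatic carbon, para to a large group and ortho to a chloro group, gives a 1.1-fold higher number from compound 1 to compound 4 (0.05 log units; within the scatter). For the compounds shown here, this is the first step between two measured compounds, and it shows that this chloro group can be replaced by hydrogen without the number moving beyond the usual scatter. It also gives compound 1 a measured partner, whereas the other compounds shown offer only limits of the assay, not numbers: the limit of > 25000 nM in this assay, at which 2 of the 4 values shown sit.

On these data alone, what a larger or different group at this position, such as an amine or a carboxylic acid, would do remains open. So does the effect of replacing the remaining chloro group of compound 4, since this single step speaks only for the one position and the one change.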